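A Small Amine Swap at the Assay Limit

The source may report more compounds than this note shows. Statements on the series, on what has been measured and on what is new or still open speak of the compounds shown alone.

Compound 1 `O=C(NO)c1cn(C2CC2)c2cc(-n3cc(CN4CCCCC4)nn3)c(F)cc2c1=O` and compound 2 `CC(C)NCc1cn(-c2cc3c(cc2F)c(=O)c(C(=O)NO)cn3C2CC2)nn1` share a core and differ only in the amine on a saturated chain carbon bound to an aromatic carbon. In a functional assay on A549 cells (Homo sapiens) for antiproliferative activity, read by MTT assay, with a stated time of 48 h (on this read-out lower numbers stand for stronger inhibition and higher numbers for weaker inhibition), compound 1 gives > 10000 nM, which is a limit of the assay and not a number. In this assay compound 2 gives > 10000 nM, which is also a limit and not a number. The picture so far is therefore (the limit of > 10000 nM in this assay, at which 2 of the 2 values shown sit).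

Compound 3 `CN(C)Cc1cn(-c2cc3c(cc2F)c(=O)c(C(=O)NO)cn3C2CC2)nn1` keeps the same core and places dimethylamino in place of isopropylamino on a saturated chain carbon bound to an aromatic carbon.

Going by the values given here, the one measured step that bears on this change is a step that the two limits leave unreadable from compound 1 to compound 2, so it offers no size to carry over. With no readable step to draw on, no shift beyond the scatter and no direction can be expected in this assay. The expected outcome is a step that the limit leaves unreadable from compound 2 to compound 3. Compound 3 is estimated at 20000 nM, with an expected range from 8000 nM to 50000 nM, and it will most likely be reported only as a limit.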

Compound 3, half-maximal inhibitory concentration: > 10000 nM
Compound 3: a limit, no number; the forecaster's own chance of this, stated with the estimate: 85%; the middle value is on the limit's open side.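

Going by these compounds alone, compound 1, compound 2 and compound 3 each give a limit and not a number, so no step among them can be read: the limit of > 10000 nM in this assay, at which 3 of the 3 values shown sit. The compounds shown leave open how these three amines on the shared core truly compare, and whether any amine there would give a measurable value in this assay.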